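Bromo in Place of Nitro: An Unmeasured Step in Guinea Pig

This account rests on a few compounds, and the source may have more. Where it says the series, first, only, none or still open, it means among the compounds named here.

Compound 1 `COc1ccc(-c2ccc(C(=O)NCCCCc3cccnc3)cc2[N+](=O)[O-])cc1OC` — 39 mg/kg
Compound 2 `CCCCc1cc(C(=O)N[C@H](C)CCCc2cccnc2)ccc1-c1ccc(OC)c(OC)c1` — 25 mg/kg

Of the compounds shown here, two have so far been measured in a functional assay on the whole organism (lung) for inhibition, with Cavia porcellus as the target; a higher number here means that more compound is needed for the effect, a lower number that less compound is needed. Compound 1 gives 39 mg/kg in this assay, the highest of the two numbers, though compound 2 at 25 mg/kg lies within the usual scatter of it, so the two cannot be told apart. Compound 3 `COc1ccc(-c2ccc(C(=O)NCCCCc3cccnc3)cc2Br)cc1OC` remains to be measured. It differs from compound 1 in a single place: bromo in place of nitro on an aromatic carbon. Among the compounds with values here, no pair of measured compounds shows what this particular exchange does, and compound 2 differs from compound 1 in several places at once, so it offers no guide. The step expected here is a 1.1-fold lower number from compound 1 to compound 3 (0.05 log units; within the scatter), which amounts to no change beyond the scatter in either direction. The estimate for compound 3 in this assay is 35 mg/kg, with a range from 15 mg/kg to 80 mg/kg.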

Compound 3, dose for 50% inhibition: 19 mg/kg
The estimate for compound 3 lay 1.8-fold (0.27 log units) above the measured number; the measured number falls inside the stated range.
By their numbers in this assay, from the lowest: compounds 3, 2 and 1 (each within the scatter of the next, the first and the last beyond it).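

In this assay, the exchange of nitro for bromo gives a 2.1-fold lower number from compound 1 to compound 3 (0.31 log units; beyond the scatter), a modest step but one that lies beyond the scatter. It shows that nitro is not needed on this aromatic carbon, ortho to a 3,4-dimethoxyphenyl group and meta to a large group: bromo, with no hydrogen-bond acceptors, takes its place and less compound is needed for the effect. Nothing on hand says what lies behind this step.

The compounds shown leave open how far the number at this position depends on the group chosen, and whether chloro, methyl, a nitrile or an amine would follow bromo or nitro. They also leave open whether the same exchange would give a similar step on any other core.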